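A few compounds are considered here, and "the series" means these few. Any claim that something is new, unique, unknown or untested is made for them only; others in the source may bear on it.

Values in a functional assay on MDA-MB-231 cells (Homo sapiens) for antiproliferative activity, read by MTT assay, with a stated time of 48 h; a lower number here means a stronger inhibitor, a higher number a weaker inhibitor:

- compound 1 `C/C(=C\CC/C(C)=C/CC[C@@H]1[C@@]2(C)CCC(=O)C(C)(C)[C@H]2CC[C@@]1(C)O)CC/C=C(\C)C(=O)OCc1cn(-c2cccc(Cl)c2)nn1`: 103000 nM
- compound 2 `C/C(=C\CC/C(C)=C/CC[C@@H]1[C@@]2(C)CCC(=O)C(C)(C)[C@H]2CC[C@@]1(C)O)CC/C=C(\C)C(=O)OCc1cn(-c2ccccc2)nn1`: > 150000 nM (a limit, not a number)
- compound 3 `C/C(=C\CC/C(C)=C/CC[C@@H]1[C@@]2(C)CCC(=O)C(C)(C)[C@H]2CC[C@@]1(C)O)CC/C=C(\C)C(=O)OCc1cn(-c2cccc(F)c2)nn1`: 144000 nM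

Compound 3, at 144000 nM, lies within the scatter of compound 1, at 103000 nM. Compound 2 gives only a limit of this assay, and (the limit of > 150000 nM in this assay, at which 1 of the 3 values shown sits).

Compound 4 `C/C(=C\CC/C(C)=C/CC[C@@H]1[C@@]2(C)CCC(=O)C(C)(C)[C@H]2CC[C@@]1(C)O)CC/C=C(\C)C(=O)OCc1cn(-c2ccccc2F)nn1` differs from compound 3 by a single change: 2-fluorophenyl in place of 3-fluorophenyl on an aromatic nitrogen. The atoms stay the same and are only joined differently.

Going by the values given here, no measured step moves a fluoro to a new place on the ring, so the available evidence is indirect. The nearest guides are changes on the same ring. Replacing chloro with fluoro gave a 1.4-fold higher number from compound 1 to compound 3 (0.15 log units; within the scatter), replacing chloro with hydrogen gave an at least 1.4-fold higher number from compound 1 to compound 2 (0.16 log units; that floor lies within the scatter), and replacing hydrogen with fluoro gave an at least 1.0-fold lower number from compound 2 to compound 3 (0.01 log units; that floor lies within the scatter). None of these goes beyond the scatter, so this small series offers no reason to expect a large effect from the new change.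

The expected size of the change is a 1.0-fold lower number from compound 3 to compound 4 (0.01 log units; within the scatter), with no direction expected beyond the scatter. A limit rather than a number is also a realistic expected outcome.

The estimated value for compound 4 is 140000 nM, with an expected range from 85000 nM to 220000 nM.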

Compound 4, half-maximal inhibitory concentration: > 150000 nM
Compound 4 was reported as a limit (the forecaster's own chance of this, stated with the estimate: 45%); middle value at least 1.0-fold (0.02 log units) from the limit.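

Swapping 3-fluorophenyl for 2-fluorophenyl on the aromatic nitrogen gives an at least 1.0-fold higher number from compound 3 to compound 4 (0.01 log units; that floor lies within the scatter) and swapping 3-chlorophenyl for 2-fluorophenyl gives an at least 1.4-fold higher number from compound 1 to compound 4 (0.16 log units; that floor lies within the scatter) at the same spot. Going by these compounds alone, this is the first measured shift of a fluoro around this ring, and the readings in this assay show no step beyond the scatter for either change, so neither one reveals a real gain or loss in strength. Compound 4 gives a limit and not a number, as compound 2 does, and the step between those two cannot be read: the limit of > 150000 nM in this assay, at which 2 of the 4 values shown sit.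

From the compounds shown here alone, how far compound 4 truly lies from compound 3 stays open, since the limit fixes only a floor and the real gap could be small or large. Also open, going by these compounds, is whether a different group on this phenyl ring, such as an amine, a carboxylic acid or a methoxy group, or a longer chain in place of the phenyl ring, would move the numbers of this series beyond the scatter.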